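Methoxy added to a series sitting at the assay limit

The source may report more compounds than this note shows. Statements on the series, on what has been measured and on what is new or still open speak of the compounds shown alone.

Of the compounds shown here, three have been tested in an assay on isolated protein for inhibition of vascular endothelial growth factor receptor 1 (Homo sapiens), read by ELISA, with a stated time of 20 min; on this read-out higher numbers stand for weaker inhibition and lower numbers for stronger inhibition. Compound 1 `COc1cc2ncnc(Nc3ccc(B(O)O)cc3)c2cc1OC` gives > 1000 nM, which is a limit of the assay and not a number. Compound 3 `COc1cc2ncnc(Nc3cccc(Cl)c3)c2cc1B1OC(C)(C)C(C)(C)O1` gives > 1000 nM, again a limit. Compound 2 `OB(O)c1ccc2ncnc(Nc3ccc(F)c(Cl)c3)c2c1` gives > 1000 nM, also a limit rather than a number. Within the data shown here, compound 2 therefore stands where every measured compound stands, since (the limit of > 1000 nM in this assay, at which 3 of the 3 values shown sit); no measured step in this assay separates any two of them, and none can be ranked against another.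

Compound 4 `COc1cc2ncnc(Nc3ccc(F)c(Cl)c3)c2cc1B(O)O` differs from compound 2 by methoxy in place of hydrogen on an aromatic carbon. Among the measured compounds shown here, no measured pair shows what this change does in this assay. With all three measured values at the limit, the step expected from compound 2 to compound 4 is a step that the limit leaves unreadable from compound 2 to compound 4, that is, none beyond the scatter, and the likeliest outcome is that this assay again reports only a limit. Compound 4 is expected to give 2000 nM in this assay, within a range from 700 nM to 6000 nM.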

Compound 4, half-maximal inhibitory concentration: > 1000 nM
Compound 4 was reported as a limit; the forecaster's own chance of this, stated with the estimate: 80%; the middle value lies beyond the limit too.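

No step can be read between compound 2 and compound 4 in this assay, since both are reported only as limits: the limit of > 1000 nM in this assay, at which 4 of the 4 values shown sit. The compounds shown leave open whether methoxy in place of hydrogen on an aromatic carbon changes inhibition at all, and what measurable value any of them would have in this assay.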